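Purine series: aniline variation on the shared core

The compounds below may be only part of what the source reports. "The series", "measured", "known", "first", "only" and "open" are said of these compounds alone.

Measured so far:
compound 1, `CC(C)CCn1cnc2c(Nc3cccc(O)c3)nc(N[C@H]3CC[C@H](N)CC3)nc21`: 12600 nM
compound 2, `CCCCn1cnc2c(Nc3ccccc3)nc(N[C@H]3CC[C@H](N)CC3)nc21`: 2200 nM

In a functional assay on MCF7 cells (Homo sapiens) for inhibition, read by fluorescence, with a stated time of 72 h (a higher number here means a weaker inhibitor of growth, a lower number a stronger inhibitor of growth), compound 1 gives 12600 nM and stands at the higher of the two numbers recorded. For the measured compounds named here, compound 2 gives 2200 nM in this assay, a lower number than compound 1; the two values differ beyond the scatter, but no single-point step links these two structures.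

Compound 3, `COc1cc(Nc2nc(N[C@H]3CC[C@H](N)CC3)nc3c2ncn3CCC(C)C)cc(OC)c1`, is not yet measured. It differs from compound 1 in one place, (3,5-dimethoxyphenyl in place of 3-hydroxyphenyl on a nitrogen on an aromatic ring).

Going by the values given here, no measured step covers this exchange, so the expectation rests only on the standing of compound 1. A modest move toward a lower number is expected, of a size close to the edge of the scatter, as a 2.1-fold lower number from compound 1 to compound 3 (0.32 log units; beyond the scatter). For compound 3 the estimated value in this assay is 6000 nM, with a range from 1500 nM to 25000 nM.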

Compound 3, concentration for 50% growth inhibition: 4500 nM
Estimate against measurement, compound 3: 1.3-fold (0.12 log units) above; low and high end bracket the measured number.
By their numbers in this assay, from the lowest: compound 2; then compound 3; then compound 1.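

In this assay, for the compounds shown here, 3,5-dimethoxyphenyl in place of 3-hydroxyphenyl on a nitrogen on an aromatic ring gives a 2.8-fold lower number from compound 1 to compound 3 (0.45 log units; beyond the scatter), the only single-place reading at this position so far. The hydroxyl-bearing group is therefore not needed to keep growth inhibition in this range, since the group with no hydrogen-bond donor gives the lower number. The change alters the donor count, acceptor count and size together, so this one step cannot assign the shift to any one of them, and no supporting data bear on its cause.

A phenyl ring with a single methoxy group, or with an amino group in place of the hydroxyl, would help separate these contributions. On these data alone, compound 2 differs from compound 1 and compound 3 in more than one place, so the separate contributions of its unsubstituted phenyl and butyl chain remain open.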